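This account rests on a few compounds, and the source may have more. Where it says the series, first, only, none or still open, it means among the compounds named here.

Among the compounds with values here, in a functional assay on C8166 cells (Homo sapiens) for cytotoxicity, read by MTT assay (on this read-out lower numbers stand for higher toxicity in this test and higher numbers for lower toxicity in this test), compound 1 `COc1ccc(C(=O)Nc2cc(Cl)ccc2OCC(=O)Nc2ccc(S(N)(=O)=O)cc2C)cc1` gives 69500 nM and compound 2 `Cc1ccc(C(=O)Nc2cc(Cl)ccc2OCC(=O)Nc2ccc(S(N)(=O)=O)cc2C)cc1C` gives 84100 nM, so compound 2 cannot be told apart from its only measured neighbour. Compound 3 `Cc1cc(S(N)(=O)=O)ccc1NC(=O)COc1ccc(Cl)cc1NC(=O)c1cc(Cl)cc(C#N)c1` changes the same place: 3-chloro-5-cyanophenyl in place of 3,4-dimethylphenyl on a carbonyl carbon. Within the data shown here, the one measured swap there, a 1.2-fold higher number from compound 1 to compound 2 (0.08 log units; within the scatter), moved the number very little, but a single step is thin evidence for a new group. The expected change is a 1.2-fold lower number from compound 2 to compound 3 (0.08 log units; within the scatter), which means no step beyond the scatter. For compound 3 the estimated value is 70000 nM, with an expected range of 25000 nM to 170000 nM.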

Compound 3, half-maximal cytotoxic concentration: 131000 nM
For compound 3 the middle estimate is 1.9-fold (0.27 log units) below the measured one, and the stated range covers the measured number.
By their numbers in this assay, from the lowest: compounds 1, 2 and 3 (each within the scatter of the next).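

In this assay, 3-chloro-5-cyanophenyl on the carbonyl carbon brings a nitrile and a chlorine to this position, yet both steps stay within the scatter: a 1.6-fold higher number from compound 2 to compound 3 (0.19 log units; within the scatter) and a 1.9-fold higher number from compound 1 to compound 3 (0.28 log units; within the scatter). This position has now carried three differently substituted phenyl groups without any step beyond the scatter, so the earlier single step no longer stands alone. No supporting measurement bears on these small differences. Still open, going by these compounds, is whether something other than a phenyl ring here, such as an amine or a carboxylic acid, would move the number beyond the scatter.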